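Isopropyl for difluorophenyl on the carbamoyl nitrogen

The compounds below may be only part of what the source reports. "The series", "measured", "known", "first", "only" and "open" are said of these compounds alone.

Measured compounds:
compound 1, `CCCCCCCN(CCCCCSc1nc(N)c2c[nH]nc2n1)C(=O)NC(C)C`, "not active" (no number reported)
compound 2, `CCCCCCCN(CCCCCSc1[nH]cnc2ncnc1-2)C(=O)NC(C)C`, 29700 nM
compound 3, `CCCCCCCN(CCCCCSc1[nH]cnc2nncc1-2)C(=O)Nc1ccc(F)cc1F`, 710 nM

In an assay on microsomes from liver for inhibition of sterol O-acyltransferase 1 (Rattus norvegicus) (a higher number here means a weaker inhibitor, a lower number a stronger inhibitor), compound 3 gives 710 nM, the lowest number among the two that were reported; compound 2 gives 29700 nM, a gap beyond the scatter. Compound 1 gives "not active" (no number reported) in this assay, so no number stands beside it.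

Compound 4, `CCCCCCCN(CCCCCSc1[nH]cnc2nncc1-2)C(=O)NC(C)C`, differs from compound 3 in one place: isopropyl in place of 2,4-difluorophenyl on an amide-type nitrogen. Among the compounds with values here, compound 4 thereby carries the core of compound 3 together with the isopropylcarbamoyl end that compounds 1 and 2 have; those two compounds, on their own cores, sit at the weak end or give no number at all, while the only compound carrying the (2,4-difluorophenyl)carbamoyl end is compound 3. Across this set, then, the isopropyl end has gone with weak or absent inhibition, though with only one compound on each core no clean separation of core from end is possible. A sizeable loss of potency, well beyond the scatter, is expected from compound 3 to compound 4, a 21-fold higher number from compound 3 to compound 4 (1.32 log units; beyond the scatter). Compound 4 is therefore estimated at 15000 nM, with a range from 3000 nM to 60000 nM, and a real chance that this assay returns no number.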

Compound 4, half-maximal inhibitory concentration: 7130 nM
The estimate for compound 4 lay 2.1-fold (0.32 log units) above the measured number, within the range that was stated.
By their numbers in this assay, from the lowest: compound 3; then compound 4; then compound 2.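

Within a single core, a 10-fold higher number from compound 3 to compound 4 (1.00 log units; beyond the scatter) in this assay gives the first clean reading at this position: the 2,4-difluorophenyl end gives the lower number, but isopropyl on the amide-type nitrogen does not abolish inhibition. With the isopropylcarbamoyl end held constant, a 4.2-fold lower number from compound 2 to compound 4 (0.62 log units; beyond the scatter) shows that the group on the sulfur also matters, so the weak result for compound 2 cannot be assigned to the isopropyl end alone. No measurement shown accounts for either step.

On these data alone, whether the lower number of compound 3 goes with the aromatic ring itself or with its fluorines remains open, and an unsubstituted phenyl or a 4-fluorophenyl on the same nitrogen would separate the two. As far as these compounds go, it is also open whether a cyclohexyl, with a ring but no aromatic carbon, would behave like the 2,4-difluorophenyl or like the isopropyl.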